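The source may hold more compounds than are shown below. What is called first, only, known or untested is meant among the compounds shown, and "the series" means these compounds.

Measured in a functional assay on HeLa cells (Homo sapiens) for antiproliferative activity, read by MTT assay, with a stated time of 72 h; a higher number here means a weaker inhibitor, a lower number a stronger inhibitor:
- compound 1 `COc1ccc(-c2c(C(=O)c3cc(OC)c(OC)c(OC)c3)sc3ccccc23)cc1`: 4200 nM
- compound 2 `COc1cc(C(=O)c2sc3ccccc3c2-c2ccc(SC)cc2)cc(OC)c1OC`: 3500 nM
- compound 3 `COc1ccc(-c2c(C(=O)c3cc(OC)c(OC)c(OC)c3)sc3ccccc23)cc1C`: 10000 nM

Compound 3 has the highest number of the three in this assay, at 10000 nM, which makes it the weakest inhibitor among them. Compound 4 `CCOc1ccc(-c2c(C(=O)c3cc(OC)c(OC)c(OC)c3)sc3ccccc23)cc1` differs from it as follows: 4-ethoxyphenyl in place of 4-methoxy-3-methylphenyl on an aromatic carbon. Within the data shown here, two measured steps bear on this, a 2.4-fold higher number from compound 1 to compound 3 (0.38 log units; beyond the scatter) and a 2.9-fold higher number from compound 2 to compound 3 (0.46 log units; beyond the scatter), and both end on the 4-methoxy-3-methylphenyl group. By contrast, a 1.2-fold lower number from compound 1 to compound 2 (0.08 log units; within the scatter). Among the measured compounds shown here, compound 4 no longer carries that group, so a modest fall in the number is expected, although no measured compound bears 4-ethoxyphenyl. The expected change is a 2.0-fold lower number from compound 3 to compound 4 (0.30 log units; within the scatter). The estimate for compound 4 is 5000 nM, within an expected range of 2200 nM to 11000 nM.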

Compound 4, half-maximal inhibitory concentration: 3000 nM
The estimate for compound 4 lay 1.7-fold (0.22 log units) above the measured number; measured number inside the range.
By their numbers in this assay, from the lowest: compounds 4, 2 and 1 (each within the scatter of the next); then compound 3.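

In this assay, 4-ethoxyphenyl in place of 4-methoxy-3-methylphenyl gives a 3.3-fold lower number from compound 3 to compound 4 (0.52 log units; beyond the scatter), so at this position the two groups differ in effect although they have the same atoms, joined differently. The ethoxy group also stands level with the other para-free comparisons: a 1.4-fold lower number from compound 1 to compound 4 (0.15 log units; within the scatter) and a 1.2-fold lower number from compound 2 to compound 4 (0.07 log units; within the scatter) both lie within the scatter. Nothing shown explains why the two arrangements differ. As far as these compounds go, whether a longer chain such as propoxy keeps the number level remains open. So does whether an amine on this ring would.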